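The source may report more compounds than this note shows. Statements on the series, on what has been measured and on what is new or still open speak of the compounds shown alone.

Measured so far:
Compound 1, `Cc1nc(C(=O)OC2CC2)c(N)c2c1C(=O)N(Cc1ccccc1)C2=O`: 202000 nM
Compound 2, `Cc1nnc(-c2nc(C)c3c(c2N)C(=O)N(Cc2ccccc2)C3=O)o1`: < 5000 nM
Compound 3, `Cc1noc(-c2nc(C)c3c(c2N)C(=O)N(CC2CCNCC2)C3=O)n1`: 160000 nM

In a physicochemical assay for solubility, using the shake flask method, in simulated intestinal fluid, measured as kinetic solubility, with a stated time of 2 h, at 25 degrees C, at pH 6.5 (on this read-out higher numbers stand for higher solubility and lower numbers for lower solubility), compound 3 gives 160000 nM, the lowest of the two numbers, with compound 1 nearest at a difference within the scatter. For compound 2 the value is a limit of the assay, not a number. Among the compounds with values here, the only measured step, an at least 40-fold lower number from compound 1 to compound 2 (1.60 log units; beyond the scatter), sits at another place on the shared core, so it does not bear directly on the present change. Compound 4, `Cc1noc(-c2nc(C)c3c(c2N)C(=O)N(Cc2ccccc2F)C3=O)n1`, differs from compound 3 by 2-fluorophenyl in place of piperidin-4-yl on a saturated chain carbon bound to an amide-type nitrogen in a ring. Within the data shown here, no measured step speaks to this change, so the expectation rests on the change alone: a lower number in this assay for compound 4, beyond the scatter, estimated as an 8.0-fold lower number from compound 3 to compound 4 (0.90 log units; beyond the scatter). Compound 4 is thus expected to give about 20000 nM, between 5000 nM and 80000 nM.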

Compound 4, solubility: < 5000 nM
Compound 4 ended at the assay's limit (the forecaster's own chance of this, stated with the estimate: 20%); middle value at least 4.0-fold (0.60 log units) from the limit.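

In this assay, the step at this position, on a saturated chain carbon bound to an amide-type nitrogen in a ring, is an at least 32-fold lower number from compound 3 to compound 4 (1.50 log units; beyond the scatter), the only step shown at this place. Compound 4 gives < 5000 nM, which is a limit of the assay and not a number. The step's full size therefore stays unknown, and only its smallest size can be read: the limit of < 5000 nM in this assay, at which 2 of the 4 values shown sit.

The step swaps the whole ring, and it cannot tell whether the nitrogen of piperidin-4-yl or the 2-fluorophenyl ring accounts for it. As far as these compounds go, whether an open-chain amine such as 2-aminoethyl at this place would give a number like that of compound 3 remains open.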